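The source may hold more compounds than are shown below. What is called first, only, known or untested is meant among the compounds shown, and "the series" means these compounds.

Three compounds have been measured in a functional assay on A-431 cells (Homo sapiens) for cytotoxicity, read by MTT assay, with a stated time of 72 h, tested at 30 uM; a higher number here means more inhibition of growth at the concentration tested, a lower number less inhibition of growth:

compound 1 `N/C(=N\NC(=S)N1CCCCCC1)c1ccccn1` gives 72.3%;
compound 2 `N/C(=N\NC(=S)N1CCOCC1)c1ccccn1` gives 78.8%;
compound 3 `N/C(=N\NC(=S)N1CCOCC1)c1ccc(F)cn1` gives 82.3%.

Compound 2 and compound 3 share one core and differ only by fluoro in place of hydrogen on an aromatic carbon. That change gave a number 3.5 percentage points higher from compound 2 to compound 3 (within the scatter), so it made no real difference to growth inhibition. Compound 1 has a different core; how the two cores differ is not broken down here. Compound 4 `N/C(=N\NC(=S)N1CCCCCC1)c1ccc(F)cn1` has not yet been measured; it is made from compound 1 by fluoro in place of hydrogen on an aromatic carbon, the same change at the same place as before. Compound 1 sits at 72.3%, and the earlier step was a number 3.5 percentage points higher from compound 2 to compound 3 (within the scatter). On that basis, for compound 4 the expected step is a number 2.7 percentage points higher from compound 1 to compound 4 (within the scatter), again within the usual scatter. Compound 4 is therefore estimated at 75%, most likely between 63% and 87%.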

Compound 4, percent growth inhibition at one concentration: 81.3%
Compound 4: middle estimate off by 6.3 percentage points, on the low side; the range from low to high includes it.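

In this assay, putting fluoro in place of hydrogen on the aromatic carbon gave a number 9 percentage points higher from compound 1 to compound 4 (within the scatter), so this change made no real difference to growth inhibition here either. Set side by side, the two steps cannot be told apart: the same change on two cores in this assay, a number 3.5 percentage points higher (within the scatter) from compound 2 to compound 3 and a number 9 percentage points higher (within the scatter) from compound 1 to compound 4, 5.5 percentage points apart, within the scatter of two such steps The change therefore carried across these two cores without a detectable shift, but this rests on only two pairs, and it shows neither that fluoro raises growth inhibition on either core nor that it would behave the same way on a third core.

From the compounds shown here alone, it remains open whether a different group at the same place, such as chloro, methoxy or an amine, would shift growth inhibition beyond the scatter. The same question stands for fluoro on another carbon of the ring.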